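A few compounds are considered here, and "the series" means these few. Any claim that something is new, unique, unknown or untested is made for them only; others in the source may bear on it.

Measured in a functional assay on a cell-free system (Platelet, plasma, Homo sapiens) for inhibition; a higher number here means a weaker inhibitor, a lower number a stronger inhibitor:

- compound 1 `O=C(Nc1cccc(OCc2ccccc2)c1)C1CCCNC1`: 128000 nM
- compound 2 `N=C(N)N1CCCC(C(=O)Nc2cccc(OCc3ccc(-c4ccccc4)cc3)c2)C1`: 1000000 nM
- compound 3 `O=C(Nc1cccc(OCc2ccc(-c3ccccc3)cc2)c1)C1CCNCC1`: 111000 nM

All three numbers are high, so these are weak inhibitors. Compound 3, at 111000 nM, lies within the usual scatter of compound 1, at 128000 nM. Both numbers are well under that of compound 2.

The next compound, compound 4 `O=C(Nc1cccc(OCc2ccc(-c3ccc(C(F)(F)F)cc3)cc2)c1)C1CCNCC1`, differs from compound 3 in one place, at the far end of the molecule: trifluoromethyl in place of hydrogen on an aromatic carbon. Trifluoromethyl takes the place of hydrogen on an aromatic carbon, para to a large group.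

Going by the values given here, only one measured step exists, a 9.0-fold lower number from compound 2 to compound 3 (0.95 log units; beyond the scatter). It changes the group on the carbonyl carbon, not this place, so its size cannot be carried over. Among the compounds with values here, no measured compound shows what a substituent at this place does. A change beyond the scatter is therefore not expected, and the direction stays uncertain.

The estimated step is a 1.2-fold lower number from compound 3 to compound 4 (0.09 log units; within the scatter). Compound 4 is estimated at 90000 nM, with an expected range from 25000 nM to 300000 nM.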

Compound 4, half-maximal inhibitory concentration: 65700 nM
The estimate for compound 4 lay 1.4-fold (0.14 log units) above the measured number; measured number inside the range.
By their numbers in this assay, from the lowest: compounds 4, 3 and 1 (each within the scatter of the next); then compound 2.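

In this assay, trifluoromethyl in place of hydrogen on an aromatic carbon, para to a large group, gives a 1.7-fold lower number from compound 3 to compound 4 (0.23 log units; within the scatter) and so leaves compound 4 not clearly separated from compound 3. This is the first substituent shown at this place, and it shows that phenyl to 4-(trifluoromethyl)phenyl, which adds four heavy atoms at the far end of the molecule, brings no change beyond the scatter, with both compounds remaining weak inhibitors. No measurement available here accounts for this result.

On these data alone, whether a different group at this place, such as an amine or a carboxylic acid, would shift the number beyond the scatter remains open. Also open, as far as these compounds go, is whether trifluoromethyl would give a similar step on compound 2, which carries a different group on its carbonyl carbon.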